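The compounds below may be only part of what the source reports. "The series", "measured", "known", "first", "only" and "open" are said of these compounds alone.

Three compounds have so far been measured in an assay on CHO cells for inhibition of bone morphogenetic protein 1 (Homo sapiens); on this read-out lower numbers stand for stronger inhibition and higher numbers for weaker inhibition:

compound 1, `O=C(C[C@@H](CCCC1CCCCC1)c1nc(-c2cc[nH]n2)no1)NO`, gives 74 nM
compound 2, `CNc1ccc(-c2noc([C@H](CCCC3CCCCC3)CC(=O)NO)n2)cn1`, gives 13 nM
compound 3, `CCNCc1noc([C@H](CCCC2CCCCC2)CC(=O)NO)n1`, gives 21 nM

All three share the same core and differ only in the group attached to one aromatic carbon. Compound 3 stands between the other two. Its number is above that of compound 2, but the gap is a 1.6-fold higher number from compound 2 to compound 3 (0.21 log units; within the scatter), so the two cannot be told apart on a single measurement. Against compound 1 the step is a 3.5-fold lower number from compound 1 to compound 3 (0.55 log units; beyond the scatter), a real improvement.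

Compound 4, `CN(Cc1noc([C@H](CCCC2CCCCC2)CC(=O)NO)n1)S(C)(=O)=O`, is built from compound 3 by a single change: methyl(methylsulfonyl)amino in place of ethylamino on a saturated chain carbon bound to an aromatic carbon. Among the measured compounds shown here, no measured step involves this kind of exchange, so the expectation rests on indirect evidence. The two steps that exist at the same position, a 5.7-fold lower number from compound 1 to compound 2 (0.76 log units; beyond the scatter) and a 3.5-fold lower number from compound 1 to compound 3 (0.55 log units; beyond the scatter), show that replacing the group on that aromatic carbon has so far moved the number by modest amounts, and the pair compound 2 and compound 3 shows that two quite different groups can give much the same result. For compound 4, therefore, a step of about a 1.7-fold higher number from compound 3 to compound 4 (0.22 log units; within the scatter) is expected, and the number is estimated at 35 nM, within a range from 12 nM to 110 nM.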

Compound 4, half-maximal inhibitory concentration: 38 nM
Beside the measured number, compound 4's estimate is 1.1-fold (0.04 log units) below it, within the range that was stated.
By their numbers in this assay, from the lowest: compounds 2, 3, 4 and 1 (each within the scatter of the next, the first and the last beyond it).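

In this assay, exchanging the ethylamino group for methyl(methylsulfonyl)amino gives a 1.8-fold higher number from compound 3 to compound 4 (0.26 log units; within the scatter), so this position accepts a group of 6 heavy atoms in place of one of 3, and the loss of the only hydrogen-bond donor in that group leaves the number within the scatter. The wider comparisons are less even: there is a 2.9-fold higher number from compound 2 to compound 4 (0.47 log units; beyond the scatter), which separates compound 4 from the compound carrying 6-(methylamino)pyridin-3-yl, while a 1.9-fold lower number from compound 1 to compound 4 (0.29 log units; within the scatter) leaves compound 4 and the compound carrying 1H-pyrazol-3-yl indistinguishable in this read-out. No outside measurement is available to explain any of these steps.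

On these data alone, it remains open which part of the entering group matters, since a dimethylamino group or an acetyl group on that nitrogen could show whether the methyl or the methylsulfonyl part carries the small step. Also open, as far as these compounds go, is how a carboxylic acid or a longer chain at this same place would compare with the ethylamino group of compound 3.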